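A few compounds are considered here, and "the series" means these few. Any claim that something is new, unique, unknown or untested is made for them only; others in the source may bear on it.

Working notes on the series.

Three compounds of this set share one core and have been run in a functional assay on Jurkat cells (Homo sapiens) for inhibition; a lower number here means a stronger inhibitor, a higher number a weaker inhibitor. Compound 1 `CC(C)[C@H](NC(=O)COc1cccc2ccccc12)C(=O)N[C@@H](CC(=O)O)C(=O)COc1nc2ccccc2[nH]1` carries a 1H-benzimidazol-2-yl on the oxygen on the saturated carbon. In this assay compound 1 gives only a limit, > 200000 nM. Compound 2 `CC(C)[C@H](NC(=O)COc1cccc2ccccc12)C(=O)N[C@@H](CC(=O)O)C(=O)COc1cc(C(F)(F)F)ncn1` carries a 6-(trifluoromethyl)pyrimidin-4-yl at that place. In this assay compound 2 likewise gives only a limit, > 200000 nM. Compound 3 `CC(C)[C@H](NC(=O)COc1cccc2ccccc12)C(=O)N[C@@H](CC(=O)O)C(=O)COc1nccc(C(F)(F)F)n1` carries a 4-(trifluoromethyl)pyrimidin-2-yl there. In this assay compound 3 also gives only a limit, > 200000 nM.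

The steps between them are therefore not readable: a step that the two limits leave unreadable from compound 1 to compound 2, a step that the two limits leave unreadable from compound 1 to compound 3 and a step that the two limits leave unreadable from compound 2 to compound 3. Among the measured compounds shown here, the one thing the numbers do show is the limit of > 200000 nM in this assay, at which 3 of the 3 values shown sit. Compound 3 thus stands where compound 1 and compound 2 stand, at the limit, with no number of its own.

Compound 4 `CC(C)[C@H](NC(=O)COc1cccc2ccccc12)C(=O)N[C@@H](CC(=O)O)C(=O)COc1cc2ccccc2cn1` is not yet measured. It differs from compound 3 by isoquinolin-3-yl in place of 4-(trifluoromethyl)pyrimidin-2-yl on an oxygen on a saturated carbon. For the measured compounds named here, none of the measured steps gives a readable size for an exchange at this place, so no direction can be taken from them. Compound 4 is expected to sit at the limit as well, an expected step of a number no higher from compound 3 to compound 4 (the limit leaves the size open). The estimate for compound 4 in this assay is 200000 nM, with a range from 50000 nM to 1000000 nM.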

Compound 4, half-maximal inhibitory concentration: > 200000 nM
Compound 4: no number, only a limit; the forecaster's own chance of this, stated with the estimate: 85%; the middle value sits exactly at the limit.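

In this assay compound 4 gives only a limit, > 200000 nM. Its steps from compound 1, compound 2 and compound 3 cannot be read, and the set remains without a single number: the limit of > 200000 nM in this assay, at which 4 of the 4 values shown sit. The compounds shown leave open whether any group on the oxygen on the saturated carbon gives a measurable value in this assay, and how large an exchange at this place can be.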